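Replacing the 2-isopropylphenyl group of compound 3

The source may hold more compounds than are shown below. What is called first, only, known or untested is meant among the compounds shown, and "the series" means these compounds.

In a functional assay on MCF7 cells (Homo sapiens) for inhibition, read by CCK-8 assay, with a stated time of 48 h (a higher number here means a weaker inhibitor of growth, a lower number a stronger inhibitor of growth), compound 1 (`CN1CCN(c2ccc(Nc3ncc(Cl)c(NCc4ccc(F)cc4)n3)nc2)CC1`) gives 19300 nM and compound 2 (`Cc1ccc(Nc2nc(Nc3ccc(N4CCN(C)CC4)cn3)ncc2Cl)cc1`) gives 11400 nM as its result, while compound 3 (`CC(C)c1ccccc1Nc1nc(Nc2ccc(N3CCN(C)CC3)cn2)ncc1Cl`) has the lowest number of the three at 4360 nM in this small series. Compound 4 (`CN1CCN(c2ccc(Nc3ncc(Cl)c(Nc4ccc(C(C)(C)C)cc4)n3)nc2)CC1`) has 4-(tert-butyl)phenyl in place of 2-isopropylphenyl on a nitrogen on an aromatic ring. The closest guide is a 2.6-fold lower number from compound 2 to compound 3 (0.42 log units; beyond the scatter) on exchanging 4-methylphenyl for 2-isopropylphenyl, and the wider comparison is a 4.4-fold lower number from compound 1 to compound 3 (0.65 log units; beyond the scatter) for that series. For the measured compounds named here, the new group looks more like the 4-methylphenyl of compound 2, though no measured compound holds a tert-butyl group. A small rise is therefore expected in this assay, with an estimated 1.5-fold higher number from compound 3 to compound 4 (0.17 log units; within the scatter) that stays within the scatter. For compound 4 the estimated value is 6500 nM with an expected range from 2200 nM to 17000 nM in this test.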

Compound 4, concentration for 50% growth inhibition: 12600 nM
The estimate for compound 4 lay 1.9-fold (0.29 log units) below the measured number; the measured number falls inside the stated range.
By their numbers in this assay, from the lowest: compound 3; then compounds 2, 4 and 1 (each within the scatter of the next).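

Exchanging 2-isopropylphenyl for 4-(tert-butyl)phenyl on this nitrogen in this assay gives a clear loss (a 2.9-fold higher number from compound 3 to compound 4 (0.46 log units; beyond the scatter)), so a branched alkyl group on the phenyl ring is not enough to keep what compound 3 gained. Tert-butyl in place of methyl changes nothing measurable (a 1.1-fold higher number from compound 2 to compound 4 (0.04 log units; within the scatter)), and 4-(tert-butyl)phenyl does no better than 4-fluorobenzyl (a 1.5-fold lower number from compound 1 to compound 4 (0.19 log units; within the scatter)). How a phenyl ring carrying an amine or a carboxylic acid would behave on this nitrogen stays open, and no measurement shown here explains these differences.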